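Styryl chromone series: bromo in place of trifluoromethyl

The source may report more compounds than this note shows. Statements on the series, on what has been measured and on what is new or still open speak of the compounds shown alone.

Compound 1 `COc1cc(OC)c2c(=O)cc(/C=C/c3ccncc3)oc2c1`: in a functional assay on A549 cells (Homo sapiens) for antiproliferative activity, read by MTT assay, with a stated time of 12 h (a higher number here means a weaker inhibitor, a lower number a stronger inhibitor), compound 1 gives > 40000 nM, a limit of the assay.
Compound 2 `COc1cc(OC)c2c(=O)cc(/C=C/c3ccc(C(F)(F)F)cc3)oc2c1`: in this assay compound 2 gives > 40000 nM, likewise a limit of the assay.

For the measured compounds named here, compound 2 therefore stands at the limit and not at a number, and the same holds for the only other measured compound: the limit of > 40000 nM in this assay, at which 2 of the 2 values shown sit. Going by the values given here, no step between measured compounds can be computed, so nothing measured sets a size or a direction for the next change.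

Compound 3 `COc1cc(OC)c2c(=O)cc(/C=C/c3ccc(Br)cc3)oc2c1` differs from compound 2 by bromo in place of trifluoromethyl on an aromatic carbon. With both measured values resting at the limit, the expected step that the limit leaves unreadable from compound 2 to compound 3 is none beyond the scatter. In this assay compound 3 is expected at 45000 nM, within the range 10000 nM to 200000 nM, and most probably reported once more as a limit rather than as a number.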

Compound 3, half-maximal inhibitory concentration: > 40000 nM
Compound 3 ended at the assay's limit; the forecaster's own chance of this, stated with the estimate: 75%; the middle value lies beyond the limit too.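

No step from compound 2 to compound 3 or from compound 1 to compound 3 can be read, as all three compounds rest at the same limit: the limit of > 40000 nM in this assay, at which 3 of the 3 values shown sit.

Open remains whether compound 1, compound 2 and compound 3 differ at all in this assay and which change to the shared core would give a number rather than a limit.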